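The source may hold more compounds than are shown below. What is called first, only, known or untested is meant among the compounds shown, and "the series" means these compounds.

Compound 1 (`N#Cc1ccc(O[C@H]2CN(S(=O)(=O)c3ccc(Cl)cc3Cl)C[C@@]2(O)CO)cc1`), compound 2 (`N#Cc1ccc(S(=O)(=O)[C@H]2CN(S(=O)(=O)c3ccc(Cl)cc3Cl)C[C@@H]2O)cc1`) and compound 3 (`N#Cc1ccc(S(=O)(=O)[C@H]2CN(S(=O)(=O)c3ccc(Cl)cc3Cl)C[C@@]2(O)CO)cc1`) have all been measured in an ADME assay on the whole organism (Rattus norvegicus, strain Sprague-Dawley) for protein binding, read by LC-MS, with a stated time of 30 min, at a dose of 1 mg/kg by the intravenous route; a lower number here means slower removal, a higher number faster removal of the compound. There, compound 3 gives 9 mL/min/kg. This lies within the scatter of compound 1 at 15 mL/min/kg, but clearly beneath compound 2 at 30 mL/min/kg, a gap beyond the scatter. Compound 4 (`N#Cc1ccc(S(=O)(=O)[C@H]2CN(S(=O)(=O)c3ccc(C#N)cc3Cl)C[C@@]2(O)CO)cc1`) differs from compound 3 in one place: cyano in place of chloro on an aromatic carbon, with cyano in place of chloro on an aromatic carbon, turning 2,4-dichlorophenyl into 2-chloro-4-cyanophenyl. Among the measured compounds shown here, no measured pair shows this change, so no shift beyond the scatter is expected in this assay. The expected step, a 1.1-fold lower number from compound 3 to compound 4 (0.05 log units; within the scatter), stays within the scatter. For compound 4, the estimated clearance is 8 mL/min/kg, with an expected range of 4 mL/min/kg to 16 mL/min/kg.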

Compound 4, clearance: 4 mL/min/kg
Compound 4: middle estimate off by 2.0-fold (0.30 log units), on the high side; measured number inside the range.
By their numbers in this assay, from the lowest: compound 4; then compounds 3, 1 and 2 (each within the scatter of the next, the first and the last beyond it).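

In this assay, the aromatic carbon para to a large group proves to be a place where the number can move: cyano in place of chloro gives a 2.3-fold lower number from compound 3 to compound 4 (0.35 log units; beyond the scatter) and takes compound 4 to the lowest number of the set. The earlier compounds shown here carried chloro here throughout, so they said nothing about this position. Nothing available explains the step.

This single pair leaves open whether fluoro, trifluoromethyl or a carboxylic acid at this carbon would move the number the same way. It also leaves open whether the same change would hold on the other cores shown.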